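Shortened chain with a substituted end: compound 4 against compound 2

The compounds below may be only part of what the source reports. "The series", "measured", "known", "first", "only" and "open" are said of these compounds alone.

In a functional assay on the whole organism (stomach) with Rattus norvegicus as the target (on this read-out higher numbers stand for an effect only at larger amounts of compound and lower numbers for an effect already at smaller amounts), compound 2 `N=C(S)CCCn1nc(-c2ccccc2)ccc1=O` gives 31.9 mg/kg, the lowest of the two numbers shown. Compound 3 `CN(C)C(=S)CCCCCn1nc(-c2ccccc2)ccc1=O` gives 100 mg/kg, so that a 3.1-fold higher number from compound 2 to compound 3 (0.50 log units; beyond the scatter). Compound 1 `N=C(S)CCCCn1nc(-c2ccccc2)ccc1=O` reaches only the limit > 100 mg/kg in this assay. The other measured step is an at least 3.1-fold lower number from compound 1 to compound 2 (0.49 log units; beyond the scatter). Compound 4 `C/N=C(\S)CCn1nc(-c2ccccc2)ccc1=O` is not yet measured; it differs from compound 2 by a group of 4 heavy atoms (2 carbon, 1 nitrogen, 1 sulfur; no ring) in place of a group of 4 heavy atoms (2 carbon, 1 nitrogen, 1 sulfur; no ring), on a saturated chain carbon, two bonds along the chain from an aromatic nitrogen. Both measured steps change the group on a saturated chain carbon of the shared core, and both moved the number by a modest amount in opposite directions. The change to compound 4 rearranges the same atoms rather than adding or removing any, so a modest shift at most is expected, with a 1.6-fold higher number from compound 2 to compound 4 (0.20 log units; within the scatter). Compound 4 is therefore expected to give 50 mg/kg, between 15 mg/kg and 150 mg/kg.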

Compound 4, dose for half-maximal effect: 58.5 mg/kg
Beside the measured number, compound 4's estimate is 1.2-fold (0.07 log units) below it; the measured number falls inside the stated range.
By their numbers in this assay, from the lowest: compounds 2, 4 and 3 (each within the scatter of the next, the first and the last beyond it).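

In this assay the rearranged end group, with 1 hydrogen-bond donor in place of 2, gives a 1.8-fold higher number from compound 2 to compound 4 (0.26 log units; within the scatter) and so stays within the scatter of the shorter-named comparison, showing that this change of joining and chain leaves the number unseparated. The step of an at least 1.7-fold lower number from compound 1 to compound 4 (0.23 log units; that floor lies within the scatter) gives only a floor and fixes no size. Compound 1 stands at a limit, not a number: the limit of > 100 mg/kg in this assay, at which 1 of the 4 values shown sits.

From the compounds shown here alone, compound 2 and compound 4 differ in chain and end group at once, so the share of each stays open. Going by these compounds, how an amine or a carboxylic acid at this place would read also stays open.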